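Adding a Methyl to Compound 2 in the Inhibition Assay

The compounds below may be only part of what the source reports. "The series", "measured", "known", "first", "only" and "open" are said of these compounds alone.

Compound 2 `N#C/C(=C\C=C(/Cl)c1ccc(Br)cc1)C(=O)c1c[nH]c2ccccc12` gives 18.4% in a functional assay for inhibition, with a stated time of 30 min, tested at 1 mM (on this read-out lower numbers stand for less inhibition and higher numbers for more inhibition at the one concentration tested (going by the name of the read-out)), and stands lowest of the three numbers shown. Compound 3 `COc1ccc(/C(Cl)=C/C=C(\C#N)C(=O)c2c[nH]c3ccccc23)cc1` gives 23.4% in this assay, and compound 2 sits nearest to it, a number 5 percentage points higher from compound 2 to compound 3 (within the scatter). Compound 1 `COc1ccc(/C(Cl)=C/C=C(\C#N)C(=O)c2c(C)[nH]c3ccccc23)cc1` gives 34.2% in this assay, the furthest from compound 2.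

Compound 4 `Cc1[nH]c2ccccc2c1C(=O)/C(C#N)=C/C=C(\Cl)c1ccc(Br)cc1` differs from compound 2 by a single change: methyl in place of hydrogen on an aromatic carbon. Within the data shown here, the one measured step that bears on this change is the reverse of the step from compound 1 to compound 3, where a number 10.8 percentage points lower from compound 1 to compound 3 (beyond the scatter). Taken backwards, that step points to more inhibition when the methyl is present rather than the hydrogen. The pair of compound 2 and compound 3 does not involve this change and only shows that the two values lie close together.

A rise of about the same size is therefore expected for compound 4, a number 9.6 percentage points higher from compound 2 to compound 4 (within the scatter). Compound 4 is estimated at 28% in this assay, with a range from 15% to 42%.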

Compound 4, a percentage reported as inhibition, at one concentration (the size of the read-out at that concentration, not a potency): 15.8%
Beside the measured number, compound 4's estimate is 12.2 percentage points above it, within the range that was stated.
By their numbers in this assay, from the lowest: compounds 4, 2 and 3 (each within the scatter of the next); then compound 1.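

On the bromo compounds in this assay, methyl in place of hydrogen on this aromatic carbon, next to the ring nitrogen, gives a number 2.6 percentage points lower from compound 2 to compound 4 (within the scatter), so the two cannot be told apart and the step beyond the scatter seen on the methoxy compounds does not appear here. With the methyl present, bromo in place of methoxy gives a number 18.4 percentage points lower from compound 1 to compound 4 (beyond the scatter), a step beyond the scatter that is not seen between the two compounds that carry hydrogen at this position. Even so, the two methyl steps do not differ by more than the scatter, so the data do not show that the effect of this change depends on the core: the same change on two cores in this assay, a number 10.8 percentage points lower (beyond the scatter) from compound 1 to compound 3 and a number 2.6 percentage points higher (within the scatter) from compound 4 to compound 2, 13.4 percentage points apart, within the scatter of two such steps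

On these data alone, whether the methyl step truly differs between the methoxy and bromo compounds stays open with only these two pairs. Also open, as far as these compounds go, is how an ethyl group or an amine on this aromatic carbon would read in this assay.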